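The compounds below may be only part of what the source reports. "The series", "measured", "known", "first", "only" and "open" are said of these compounds alone.

Compound 1 `N#Cc1cnc(NCc2ccccc2C(F)(F)F)cc1N[C@H]1CC[C@@H](O)CC1`: 140 nM
Compound 2 `N#Cc1cnc(NCc2ccccc2C(F)(F)F)cc1N[C@H]1CC[C@@H](C(N)=O)CC1`: 20 nM

Both numbers come from an assay on isolated protein for inhibition of protein kinase C theta type (Homo sapiens), read by TR-FRET, with a stated time of 2 h; a lower number here means a stronger inhibitor, a higher number a weaker inhibitor. Among the measured compounds shown here, of the two, compound 1 has the higher number; the one measured step, a 7.0-fold lower number from compound 1 to compound 2 (0.85 log units; beyond the scatter), puts a carbamoyl in place of a hydroxy on a saturated ring carbon and lies beyond the scatter. Compound 3 `N#Cc1cnc(NCc2ccccc2)cc1N[C@H]1CC[C@@H](O)CC1` alters compound 1 at a different place: hydrogen in place of trifluoromethyl on an aromatic carbon. For the measured compounds named here, no measured step touches this part of the molecule, so the step from compound 1 to compound 2 gives no direct guidance, and the expectation rests on the structural change alone with wide uncertainty. A modest weakening is expected, a step of a 2.9-fold higher number from compound 1 to compound 3 (0.46 log units; beyond the scatter) in this assay. Compound 3 is therefore estimated at 400 nM, with a range from 100 nM to 1500 nM.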

Compound 3, half-maximal inhibitory concentration: 7000 nM
The estimate for compound 3 lay 18-fold (1.24 log units) below the measured number, outside the stated range (above it).
By their numbers in this assay, from the lowest: compound 2; then compound 1; then compound 3.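

In this assay, hydrogen in place of trifluoromethyl on an aromatic carbon gives a large loss (a 50-fold higher number from compound 1 to compound 3 (1.70 log units; beyond the scatter)), which shows that this position, untouched by the earlier pair, has a strong bearing on the number. Among the compounds shown here, the change is bigger in size than the earlier change on the saturated ring carbon (a 7.0-fold lower number from compound 1 to compound 2 (0.85 log units; beyond the scatter)), although these are only two steps in a very small set. Nothing measured here explains why removing trifluoromethyl costs so much.

From the compounds shown here alone, whether the full trifluoromethyl group is needed stays open, since a methyl group, a chlorine atom or a methoxy group at this place would separate its effect from that of simply having some group there. Going by these compounds, it is also open whether the same loss would appear with carbamoyl on the saturated ring, as in compound 2.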